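2-Nitrophenyl in place of 2,5-dimethoxyphenyl: working notes

The compounds below may be only part of what the source reports. "The series", "measured", "known", "first", "only" and "open" are said of these compounds alone.

- Compound 1 `COc1ccc(OC)c(/C=C/C(=O)Nc2cc3c(Nc4ccc(F)c(Cl)c4)ncnc3cc2OC)c1` gives 34300 nM
- Compound 2 `COc1cc(/C=C/C(=O)Nc2cc3c(Nc4ccc(F)c(Cl)c4)ncnc3cc2O[C@H]2CCOC2)cc(OC)c1OC` gives 28400 nM

Both values come from a functional assay on MCF7 cells (Homo sapiens) for cytotoxicity, read by MTT assay, with a stated time of 72 h (on this read-out lower numbers stand for stronger inhibition and higher numbers for weaker inhibition), and lie within the usual scatter of each other, so compound 1 stands level with compound 2 and no order can be drawn between them. Compound 3 `COc1cc2ncnc(Nc3ccc(F)c(Cl)c3)c2cc1NC(=O)/C=C/c1ccccc1[N+](=O)[O-]` has not been measured yet. Relative to compound 1 it carries 2-nitrophenyl in place of 2,5-dimethoxyphenyl on a double-bonded chain carbon bound to a double-bonded chain carbon while the rest of the structure stays the same. Within the data shown here, no measured pair in this assay shows what such an exchange does. A change beyond the scatter is therefore not expected in either direction. Among the measured compounds shown here, the only reference level is compound 1 at 34300 nM and compound 2 at 28400 nM in this series. The estimated step of a 1.1-fold lower number from compound 1 to compound 3 (0.06 log units; within the scatter) stays within the scatter. Compound 3 is expected at 30000 nM within an estimated range of 10000 nM to 70000 nM in this assay.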

Compound 3, half-maximal inhibitory concentration: 36500 nM
For compound 3 the middle estimate is 1.2-fold (0.09 log units) below the measured one; the measured number falls inside the stated range.
By their numbers in this assay, from the lowest: compounds 2, 1 and 3 (each within the scatter of the next).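

In this assay, among these compounds, 2-nitrophenyl in place of 2,5-dimethoxyphenyl on a double-bonded chain carbon bound to a double-bonded chain carbon gives a 1.1-fold higher number from compound 1 to compound 3 (0.03 log units; within the scatter), the first readable exchange at this position. The two groups cannot be told apart here: the exchange of both methoxy groups for a single nitro group leaves the number within the scatter, so this read-out offers no ranking of the two. Nothing on hand bears on why this exchange leaves the number within the scatter.

Open, on these data alone, is whether an amine, a carboxylic acid or an unsubstituted phenyl at this same place would bring a step beyond the scatter in this assay. Also open, as far as these compounds go, is whether any group at this place can bring the number far from the level shared by compound 1 and compound 3.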